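The source may report more compounds than this note shows. Statements on the series, on what has been measured and on what is new or still open speak of the compounds shown alone.

In a functional assay on HL-60 cells (Homo sapiens) for antiproliferative activity, read by MTT assay, with a stated time of 72 h (a higher number here means a weaker inhibitor, a lower number a stronger inhibitor), compound 1 `N=C(NS(=O)(=O)c1ccccc1Cl)N1CCN(c2cc3c(cc2F)c(=O)c(C(=O)O)cn3C2CC2)CC1` gives 43 nM and compound 2 `N=C(NS(=O)(=O)c1cccc(Cl)c1)N1CCN(c2cc3c(cc2F)c(=O)c(C(=O)O)cn3C2CC2)CC1` gives 43 nM, so compound 2 stands level with compound 1. Compound 3 `N=C(NS(=O)(=O)c1ccc(C(F)(F)F)cc1)N1CCN(c2cc3c(cc2F)c(=O)c(C(=O)O)cn3C2CC2)CC1` carries 4-(trifluoromethyl)phenyl in place of 3-chlorophenyl on a sulfonyl sulfur. Going by the values given here, only one measured step bears on this group, no change at the digits printed from compound 1 to compound 2 (within the scatter), and no measured compound carries trifluoromethyl, so the evidence is thin. On that basis, no step beyond the scatter is expected in this assay. The estimated step is a 1.0-fold higher number from compound 2 to compound 3 (0.02 log units; within the scatter). Compound 3 is expected at about 45 nM, within an estimated range of 15 nM to 135 nM.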

Compound 3, half-maximal inhibitory concentration: 43 nM
Beside the measured number, compound 3's estimate is 1.0-fold (0.02 log units) above it; measured number inside the range.
By their numbers in this assay, from the lowest: compounds 1, 2 and 3 (each within the scatter of the next).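

In this assay the change on the sulfonyl sulfur now goes beyond moving a chlorine: 4-(trifluoromethyl)phenyl in place of 3-chlorophenyl gives no change at the digits printed from compound 2 to compound 3 (within the scatter) and in place of 2-chlorophenyl gives no change at the digits printed from compound 1 to compound 3 (within the scatter). Across these three compounds, therefore, a different group at a different ring position leaves the number within the scatter. No evidence shown explains this lack of difference. Still open, going by these compounds, is whether a phenyl ring carrying an amine or a carboxylic acid would behave the same way. Also open, on these data alone, is the effect of replacing the ring with a plain alkyl chain.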